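A few compounds are considered here, and "the series" means these few. Any claim that something is new, unique, unknown or untested is made for them only; others in the source may bear on it.

Of the compounds shown here, two have been measured in a physicochemical assay for solubility; on this read-out lower numbers stand for lower solubility and higher numbers for higher solubility. Compound 1 `COc1cc(/C=C/C(=O)N(/N=N/c2cc(C(F)(F)F)ccc2Cl)c2cc(C(F)(F)F)ccc2Cl)ccc1OC(C)=O` gives 40300 nM, the higher of the two numbers; compound 2 `COc1cc(/C=C/C(=O)N(/N=N/c2ccc(Cl)c(C(F)(F)F)c2)c2ccc(Cl)c(C(F)(F)F)c2)ccc1OC(C)=O` gives 16800 nM, and the gap between these two lies beyond the scatter. Compound 3 `COc1ccc(/C=C/C(=O)N(/N=N/c2cc(C(F)(F)F)ccc2Cl)c2cc(C(F)(F)F)ccc2Cl)cc1OC` has not yet been measured in this assay. It differs from compound 1 in one place: methyl in place of acetyl on an oxygen on an aromatic ring. Among the measured compounds shown here, no measured pair shows this change, so the size of the step is open; a small step, not clearly beyond the scatter, is expected, written as a 1.1-fold higher number from compound 1 to compound 3 (0.05 log units; within the scatter). For compound 3 the estimate in this assay is 45000 nM, with a range from 15000 nM to 120000 nM.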

Compound 3, solubility: 28100 nM
For compound 3 the middle estimate is 1.6-fold (0.20 log units) above the measured one; measured number inside the range.
By their numbers in this assay, from the lowest: compounds 2, 3 and 1 (each within the scatter of the next, the first and the last beyond it).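

Working notes on the oxygen on the aromatic ring: in this assay the acetoxy to methoxy change gives a 1.4-fold lower number from compound 1 to compound 3 (0.16 log units; within the scatter) and is the first step read at this position. Methyl and acetyl on this oxygen therefore cannot be told apart in this assay on the core of compound 1. No supporting evidence bears on this step.

Still open, on these data alone, is whether a longer chain or a chain ending in an amine or a carboxylic acid on this oxygen would give a step beyond the scatter. Also open, as far as these compounds go, is whether acetoxy to methoxy reads the same on the core of compound 2.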